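Sulfonyl aryl swap on a quinoline core: predicting compound 4

This account rests on a few compounds, and the source may have more. Where it says the series, first, only, none or still open, it means among the compounds named here.

Measured so far:
Compound 1 `Cc1ccc(S(=O)(=O)c2cnc3ccc(Cl)cc3c2N2CCC(C)CC2)cc1F` — 68%
Compound 2 `Cc1cc(C)cc(S(=O)(=O)c2cnc3ccc(F)cc3c2N2CCC(C)CC2)c1` — 83%
Compound 3 `CC1CCN(c2c(S(=O)(=O)c3ccc(F)cc3)cnc3ccc(Cl)cc23)CC1` — 89%

In an assay on isolated protein for displacement of a labelled ligand from metabotropic glutamate receptor 5 (Homo sapiens), with a stated time of 60 min, tested at 1 uM (on this read-out higher numbers stand for more inhibition at the one concentration tested (going by the name of the read-out) and lower numbers for less inhibition), compound 3 gives the highest of the three numbers; compound 2 lies within the scatter of it, while compound 1 lies beyond it, as a number 21 percentage points higher from compound 1 to compound 3 (beyond the scatter) shows. Compound 4 `Cc1cc(C)cc(S(=O)(=O)c2cnc3ccc(Cl)cc3c2N2CCC(C)CC2)c1` differs from compound 3 in one place: 3,5-dimethylphenyl in place of 4-fluorophenyl on a sulfonyl sulfur. Among the compounds with values here, the only measured step on the sulfonyl aryl group, a number 21 percentage points higher from compound 1 to compound 3 (beyond the scatter), concerns a different pair of groups and so bears only loosely on it. Compound 2 carries the entering 3,5-dimethylphenyl on a fluorine-bearing core and gives 83%, close to compound 3. No change beyond the scatter is therefore expected: compound 4 is estimated at 84% (range 72% to 95%), a step of a number 5 percentage points lower from compound 3 to compound 4 (within the scatter).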

Compound 4, a percentage reported as inhibition, at one concentration (the size of the read-out at that concentration, not a potency): 49%
Compound 4: middle estimate off by 35 percentage points, on the high side; the whole stated range lies above it.
By their numbers in this assay, from the lowest: compound 4; then compound 1; then compounds 2 and 3 (each within the scatter of the next).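

In this assay, within the data shown here, with the chloro held fixed, 3,5-dimethylphenyl on the sulfonyl sulfur costs far more than the earlier compounds suggested: a number 40 percentage points lower from compound 3 to compound 4 (beyond the scatter), and a number 19 percentage points lower from compound 1 to compound 4 (beyond the scatter). The fluoro analogue gave no warning of this, as a number 34 percentage points lower from compound 2 to compound 4 (beyond the scatter), so the aryl group and the halogen do not act independently in these compounds. No measurement shown here accounts for this.

As far as these compounds go, it remains open whether 4-fluorophenyl would also depend on the halogen. A methoxy or a nitrile on the sulfonyl aryl group is also untested among these compounds.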